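A few compounds are considered here, and "the series" means these few. Any claim that something is new, unique, unknown or untested is made for them only; others in the source may bear on it.

Compound 1 `Fc1ccc(C(SCCNC2CCN(Cc3ccccc3)CC2)c2ccc(F)cc2)cc1` and compound 2 `Fc1ccc(C(SCCNC2CCN(Cc3cc4ccccc4o3)CC2)c2ccc(F)cc2)cc1` share a core and differ only in the group on the ring nitrogen. In an assay on membranes from Cortex for displacement of a labelled ligand from Sigma non-opioid intracellular receptor 1 (Cavia porcellus), read by scintillation counting, with a stated time of 120 min (on this read-out lower numbers stand for stronger inhibition and higher numbers for weaker inhibition), compound 1 gives 3.81 nM, while compound 2 gives 205 nM; the step of a 54-fold higher number from compound 1 to compound 2 (1.73 log units; beyond the scatter) is large, and compound 2 therefore stands as the higher, weaker, of the two numbers. Compound 3 `CC(C)(C)C(=O)N1CCC(NCCSC(c2ccc(F)cc2)c2ccc(F)cc2)CC1` carries the change ((tert-butyl)carbonyl in place of (1-benzofuran-2-yl)methyl on an amine nitrogen in a ring). Within the data shown here, no measured pair shows this exact exchange, so the only guide is the step from compound 1 to compound 2, which shows that what sits on this ring nitrogen can move the number strongly. Since compound 1 is the only case where a small group at this position gave a low number, compound 3 is expected to lie somewhat below compound 2, with an estimated step of a 1.4-fold lower number from compound 2 to compound 3 (0.14 log units; within the scatter) in this assay. For compound 3 the estimate is 150 nM, with a likely range from 30 nM to 800 nM.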

Compound 3, inhibition constant: 163 nM
Compound 3: the middle estimate sits 1.1-fold (0.04 log units) below what was measured; measured number inside the range.
By their numbers in this assay, from the lowest: compound 1; then compounds 3 and 2 (each within the scatter of the next).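

In this assay, the step of a 1.3-fold lower number from compound 2 to compound 3 (0.10 log units; within the scatter) lies within the scatter, so two very different groups on this amine nitrogen in a ring, the ring-free (tert-butyl)carbonyl and the two-ring (1-benzofuran-2-yl)methyl, cannot be told apart. The step of a 43-fold higher number from compound 1 to compound 3 (1.63 log units; beyond the scatter) lies beyond the scatter, so among these three compounds benzyl now stands alone in giving a low number, and the loss seen with compound 2 is no longer tied to a single replacement group. No measurement here explains why benzyl differs from the other two groups.

As far as these compounds go, it remains open how much of the benzyl group is needed. A benzoyl group, which has a carbonyl in place of the chain carbon, or a 2-phenylethyl group, with a longer chain to the phenyl ring, could help to show this.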